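Pyrrolidine amide replaces cyclohexylamide in an edema series

A few compounds are considered here, and "the series" means these few. Any claim that something is new, unique, unknown or untested is made for them only; others in the source may bear on it.

Compound 1 `CCCCCNC(=O)CC1CCc2cc(OC)c(OC)cc21`: 40.6%
Compound 2 `COc1cc2c(cc1OC)C(CC(=O)NC1CCCCC1)CC2`: 50%

Going by the values given here, in a functional assay on the whole organism (strain Wistar) for inhibition, with Rattus norvegicus as the target, read by paw edema, with stated times of 60 min and 4 h, at a dose of 100 mg/kg by the oral route (on this read-out lower numbers stand for less inhibition and higher numbers for more inhibition at the one dose given (going by the name of the read-out)), compound 2 holds the higher of the two numbers, though the only measured step, a number 9.4 percentage points higher from compound 1 to compound 2 (within the scatter), lies within the scatter, so the two compounds cannot be ranked. Compound 3 `COc1cc2c(cc1OC)C(CC(=O)N1CCCC1)CC2` carries the change (pyrrolidin-1-yl in place of cyclohexylamino on a carbonyl carbon). Among the compounds with values here, the measured step swapped one group on the amide-type nitrogen for another while keeping the hydrogen-bond donor; here that donor leaves, and no measured step speaks to such a change. With only a within-scatter step to go on, the expected step of a number 8 percentage points lower from compound 2 to compound 3 (within the scatter) is small, and compound 3 is estimated at 42%, between 22% and 62%.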

Compound 3, a percentage reported as inhibition, in the whole organism at one dose (the size of the read-out at that dose, not a potency): 24.2%
Estimate against measurement, compound 3: 17.8 percentage points above; measured number inside the range.
By their numbers in this assay, from the lowest: compound 3; then compounds 1 and 2 (each within the scatter of the next).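

In this assay, the group on the carbonyl carbon can matter: pyrrolidin-1-yl brings a number 25.8 percentage points lower from compound 2 to compound 3 (beyond the scatter) and a number 16.4 percentage points lower from compound 1 to compound 3 (beyond the scatter), whereas exchanging pentyl for cyclohexyl gave no step beyond the scatter. Both new steps remove the hydrogen-bond donor and also place the amide nitrogen inside a five-membered ring, so these two changes cannot be told apart. No measurement here explains the drop.

On these data alone, whether the lost amide hydrogen or the ring matters more stays open. Piperidin-1-yl or diethylamino on the same carbonyl carbon would extend the comparison.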